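Swapping nitro for amino: what should compound 3 do?

A few compounds are considered here, and "the series" means these few. Any claim that something is new, unique, unknown or untested is made for them only; others in the source may bear on it.

Compound 1 `COc1ccc(/C(F)=C(/F)c2cc(OC)c(OC)c(OC)c2)cc1N`: 3600 nM
Compound 2 `COc1ccc(/C(F)=C(\F)c2cc(OC)c(OC)c(OC)c2)cc1[N+](=O)[O-]`: 2300000 nM

In a functional assay on cells (Endothelial cell, Bos taurus) for antiproliferative activity (a higher number here means a weaker inhibitor, a lower number a stronger inhibitor), compound 2 (2300000 nM) has the higher of the two numbers, so it is the weaker inhibitor, and its gap to compound 1 (3600 nM) lies well beyond the scatter. Compound 3 `COc1ccc(/C(F)=C(\F)c2cc(OC)c(OC)c(OC)c2)cc1N` is compound 2 with one change: amino in place of nitro on an aromatic carbon, ortho to a methoxy group (amino in place of nitro on an aromatic carbon). Within the data shown here, no measured pair shows this swap on its own, so the step in this assay can only be judged indirectly. Compound 1 also carries an amino group and sits at 3600 nM in this test, so a large drop beyond the scatter is expected. The estimated size of this drop is a 58-fold lower number from compound 2 to compound 3 (1.76 log units; beyond the scatter) in the direction of stronger inhibition. For compound 3 the expected value is 40000 nM (estimated range 5000 nM to 300000 nM).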

Compound 3, half-maximal inhibitory concentration: 204000 nM
Compound 3: the middle estimate sits 5.1-fold (0.71 log units) below what was measured; the measured number falls inside the stated range.
By their numbers in this assay, from the lowest: compound 1; then compound 3; then compound 2.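

In this assay, compound 1 and compound 2 differ in two places at once, so their gap could not be split between the ring substituent and the double bond. Compound 3 separates the two: with the double bond kept as in compound 2, amino in place of nitro alone gives an 11-fold lower number from compound 2 to compound 3 (1.05 log units; beyond the scatter) on this aromatic carbon, so the swap matters by itself. With the amino group kept, the E rather than Z double bond gives a 57-fold higher number from compound 1 to compound 3 (1.75 log units; beyond the scatter) as well, and only the arrangement about the double bond can account for that step: the fact that compounds 1 and 3 differ only in the configuration as drawn.

The compounds shown leave open how large the nitro-to-amino step would be on the Z double bond. They also leave open how a hydroxyl or an acetamide group would compare with amino at this place.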